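Trimming the Amide: Cyclopentyl Gives Way to Ethyl

The source may hold more compounds than are shown below. What is called first, only, known or untested is meant among the compounds shown, and "the series" means these compounds.

Among the compounds with values here, in an assay for inhibition of serine/threonine-protein kinase PLK2 (Homo sapiens), read by FRET and Z'-LYTE, with a stated time of 1 h (a higher number here means a weaker inhibitor, a lower number a stronger inhibitor), compound 2 `CC[C@@H]1C(=O)N(C)c2cnc(-n3ccc4cc(C(=O)NC5CCCC5)ccc43)nc2N1C1CCCC1` gives 7.06 nM, the lower of the two numbers measured so far, while compound 1 `CCC1C(=O)N(C)c2cnc(-n3ccc4cc(C(=O)NCC(C)C)ccc43)nc2N1c1ccn(C)n1` gives 159 nM, a gap well beyond the usual scatter. Compound 3 `CCNC(=O)c1ccc2c(ccn2-c2ncc3c(n2)N(C2CCCC2)[C@H](CC)C(=O)N3C)c1` keeps the core of compound 2 and differs in one place: ethyl in place of cyclopentyl on an amide-type nitrogen. Within the data shown here, no measured pair shows this change on its own, so a modest weakening, not a large one, is expected. Compound 3 is estimated at 20 nM, within 7 nM to 60 nM. That estimate corresponds to an expected step of a 2.8-fold higher number from compound 2 to compound 3 (0.45 log units; beyond the scatter).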

Compound 3, half-maximal inhibitory concentration: 4.88 nM
Estimate against measurement, compound 3: 4.1-fold (0.61 log units) above, outside the stated range (below it).
By their numbers in this assay, from the lowest: compounds 3 and 2 (each within the scatter of the next); then compound 1.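

On the amide-type nitrogen, ethyl can stand in place of cyclopentyl, with a 1.4-fold lower number from compound 2 to compound 3 (0.16 log units; within the scatter) in this assay. The ring is therefore not required at this position for a number as low as that of compound 2, and a group of two heavy atoms serves as well as one of five. Nothing measured here explains why the two groups read alike. Going by these compounds, it remains open whether a still smaller methyl would hold up in the same way, or whether the limit lies with a longer chain ending in an amine or a carboxylic acid.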